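Bromo for Methyl on the Sulfonyl Aryl Ring

The compounds below may be only part of what the source reports. "The series", "measured", "known", "first", "only" and "open" are said of these compounds alone.

Measured in a functional assay on HL-60 cells (Homo sapiens) for cytotoxicity, read by MTT assay, with a stated time of 72 h; a higher number here means a weaker inhibitor, a lower number a stronger inhibitor:
- compound 1, `COc1cc(Nc2nc3ccccc3nc2S(=O)(=O)c2ccc(C)cc2)cc(OC)c1`: 20 nM
- compound 2, `COc1cc(Nc2nc3ccccc3nc2S(=O)(=O)c2ccc(C)cc2)cc(OC)c1OC`: 320 nM
- compound 3, `Cc1ccc(S(=O)(=O)c2nc3ccccc3nc2Nc2ccc(F)cc2)cc1`: 5100 nM

Compound 2 stands second highest of these three numbers. The step of a 16-fold higher number from compound 1 to compound 2 (1.20 log units; beyond the scatter) separates it from the lowest value, while compound 3 sits higher still. Compound 4, `COc1cc(Nc2nc3ccccc3nc2S(=O)(=O)c2ccc(Br)cc2)cc(OC)c1OC`, differs from compound 2 by bromo in place of methyl on an aromatic carbon. Neither measured step touches this ring: a 16-fold higher number from compound 1 to compound 2 (1.20 log units; beyond the scatter) and a 260-fold higher number from compound 1 to compound 3 (2.41 log units; beyond the scatter) both changed the ring attached to the nitrogen, leaving the (4-methylphenyl)sulfonyl group untouched. For the measured compounds named here, no measured step therefore bears directly on this change. The step is expected to be a 1.1-fold higher number from compound 2 to compound 4 (0.04 log units; within the scatter). Compound 4 is estimated at 350 nM, with a range from 100 nM to 1200 nM.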

Compound 4, half-maximal inhibitory concentration: 1020 nM
Compound 4: the middle estimate sits 2.9-fold (0.46 log units) below what was measured; the range from low to high includes it.
By their numbers in this assay, from the lowest: compound 1; then compound 2; then compound 4; then compound 3.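

For the compounds shown here, the sulfonyl aryl ring, untouched in the earlier steps, also affects the result: with the rest of compound 2 held fixed, bromo in place of methyl at the carbon para to a large group gives a 3.2-fold higher number from compound 2 to compound 4 (0.50 log units; beyond the scatter) in this assay. On this background, the methyl group therefore gives the lower number and the stronger inhibitor of the two. Nothing available explains this difference.

On these data alone, it remains open whether the same change would have a similar effect in compound 1. Also unresolved is how a chlorine, an amine or a carboxylic acid at this carbon would compare.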